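The compounds below may be only part of what the source reports. "The series", "measured", "known", "first", "only" and "open" are said of these compounds alone.

Measured compounds:

- compound 1, `COC(=O)[C@@]1(C)CCC=C2[C@@H]1CC[C@@H](C)[C@]2(C)Cc1c[nH]c2ccccc12` — in a functional assay on SW1573 cells (Homo sapiens) for inhibition, read by sulforhodamine B assay, with a stated time of 48 h (a higher number here means a weaker inhibitor of growth, a lower number a stronger inhibitor of growth), compound 1 gives 7300 nM
- compound 2, `COC(=O)[C@@]1(C)CCC=C2[C@@H]1CC[C@@H](C)[C@]2(C)Cc1c[nH]c2ccc(Cl)cc12` — compound 2 gives 11000 nM
- compound 3, `COC(=O)[C@@]1(C)CCC=C2[C@@H]1CC[C@@H](C)[C@]2(C)Cc1c[nH]c2ccc(F)cc12` — compound 3 gives 7300 nM

Going by the values given here, compound 3 stands level with compound 1: the two share the lowest number of the three, and the only remaining step among them is a 1.5-fold lower number from compound 2 to compound 3 (0.18 log units; within the scatter), within the scatter, so no order among the three can be read from these numbers.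

The next step is to compound 4, `COC(=O)[C@@]1(C)CCC=C2[C@@H]1CC[C@@H](C)[C@]2(C)Cc1c[nH]c2ccc(OC)cc12`. The change from compound 3 is methoxy in place of fluoro on an aromatic carbon.

Among the compounds with values here, no measured step exchanges fluoro for methoxy, so the evidence is indirect. Within the data shown here, the steps that touch the same place are a 1.5-fold higher number from compound 1 to compound 2 (0.18 log units; within the scatter) and no change at the digits printed from compound 1 to compound 3 (within the scatter), both within the scatter; the only substituent swap at that place is a 1.5-fold lower number from compound 2 to compound 3 (0.18 log units; within the scatter), also within the scatter. Among the measured compounds shown here, nothing in this small set shows that the group at this place moves the number beyond the scatter, and there is no precedent for methoxy.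

On that basis no change beyond the scatter is expected: the estimated step is a 1.1-fold higher number from compound 3 to compound 4 (0.04 log units; within the scatter). Compound 4 is therefore expected to give about 8000 nM, with a range from 3500 nM to 18000 nM.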

Compound 4, concentration for 50% growth inhibition: 1300 nM
Beside the measured number, compound 4's estimate is 6.2-fold (0.79 log units) above it; measured number below the stated range.
By their numbers in this assay, from the lowest: compound 4; then compounds 1, 3 and 2 (each within the scatter of the next).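

In this assay this position, on an aromatic carbon meta to a fused ring and para to a fused ring, no longer looks indifferent to what it carries: methoxy gives a 5.6-fold lower number from compound 1 to compound 4 (0.75 log units; beyond the scatter) against hydrogen and a 5.6-fold lower number from compound 3 to compound 4 (0.75 log units; beyond the scatter) against fluoro, and also an 8.5-fold lower number from compound 2 to compound 4 (0.93 log units; beyond the scatter) against chloro. All three steps lie beyond the scatter, whereas hydrogen, fluoro and chloro stay within the scatter of one another, so the change in this set is confined to methoxy and compound 4 alone stands apart. Methoxy brings two heavy atoms and one hydrogen-bond acceptor in place of the single heavy atom and no acceptor of fluoro, but no measurement here accounts for the lower number.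

These compounds do not separate the contribution of the oxygen from that of the added carbon, and a hydroxy group, a methyl group or a longer chain such as ethoxy at the same place would address that. Also open, from the compounds shown here alone, is whether methoxy on another aromatic carbon of the same ring gives a similar step, or whether an amine at this place does.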